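This account rests on a few compounds, and the source may have more. Where it says the series, first, only, none or still open, it means among the compounds named here.

Measured so far:
Compound 1, `C=CCn1c(=O)/c(=C\c2cccc(C)c2)[nH]c(=O)/c1=C\c1ccccc1OC`: 16700 nM
Compound 2, `COc1ccccc1/C=c1/[nH]c(=O)/c(=C\c2ccccc2OC)[nH]c1=O`: "not active" (no number reported)
Compound 3, `COc1ccccc1/C=c1\c(=O)[nH]/c(=C/c2cccc(Cl)c2Cl)c(=O)n1C`: 200 nM

Of the compounds shown here, three sharing one core have been tested in a functional assay on HL-60 cells (Homo sapiens) for cytotoxicity, read by CCK-8 assay, with a stated time of 72 h; on this read-out higher numbers stand for weaker inhibition and lower numbers for stronger inhibition. Compound 1 gives 16700 nM, the higher of the two numbers that were obtained; compound 3 gives 200 nM, a gap well beyond the usual scatter of this assay. Compound 2 is reported only as "not active" (no number reported), with no number attached.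

The next compound, compound 4, is `C=CCn1c(=O)/c(=C\c2cccc(F)c2)[nH]c(=O)/c1=C\c1ccccc1OC`. It differs from compound 1 in a single place: fluoro in place of methyl on an aromatic carbon. Within the data shown here, no pair of measured compounds differs in exactly this way, so there is no measured step to lean on; the expectation rests on the size of the change alone. Both groups count one heavy atom, carry no ring, add no hydrogen-bond donor or acceptor and no charge. For so small an exchange the step from compound 1 to compound 4 is expected to be about a 1.1-fold lower number from compound 1 to compound 4 (0.05 log units; within the scatter), that is, not beyond the scatter in either direction. Compound 4 is therefore estimated at 15000 nM in this assay, within a range from 5000 nM to 50000 nM.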

Compound 4, half-maximal inhibitory concentration: 8890 nM
The estimate for compound 4 lay 1.7-fold (0.23 log units) above the measured number, and the stated range covers the measured number.
By their numbers in this assay, from the lowest: compound 3; then compounds 4 and 1 (each within the scatter of the next).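

In this assay, among these compounds, the exchange of 3-methylphenyl for 3-fluorophenyl gives a 1.9-fold lower number from compound 1 to compound 4 (0.27 log units; within the scatter), the first step in this set that isolates a single place, so compound 1 and compound 4 cannot be told apart on this read-out. At this position on the aromatic ring, meta to a large group, one single-heavy-atom substituent without a ring, hydrogen-bond donors or acceptors, or net charge can therefore take the place of another without a shift beyond the scatter; this one pair says nothing about other substituents at the same position. No measurement of any property of these compounds accompanies the result, and nothing shown bears on what lies behind it.

The compounds shown leave open whether an amine, a carboxylic acid or a longer chain such as n-butyl at this same place would move the number beyond the scatter, since methyl and fluoro are the only two groups compared here with all else held constant. Compound 3 differs from compound 1 and compound 4 in more than one place, so its value cannot show how much this position contributes on its own.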